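The source may report more compounds than this note shows. Statements on the series, on what has been measured and on what is new or still open speak of the compounds shown alone.

Among the compounds with values here, compound 1 `COc1ccccc1C(=O)NCc1ccc(CNS(=O)(=O)c2cccc(Cl)c2)cc1` is one of three compounds measured in an assay on MDA-MB-231 cells for displacement of a labelled ligand from C-X-C chemokine receptor type 4 (Homo sapiens), read by fluorescence and microscopy, with stated times of 10 min and 30 min; a lower number here means that less compound is needed, a higher number that more compound is needed for the effect. In this assay compound 1 gives 1000 nM, level with compound 2 `Cc1ccccc1C(=O)NCc1ccc(CNS(=O)(=O)c2ccccc2Cl)cc1`, which gives 1000 nM; together they hold the highest of the three numbers, while compound 3 `Cc1ccccc1C(=O)NCc1ccc(CNS(=O)(=O)c2cccc3ccccc23)cc1` gives 100 nM. Within the data shown here, the only measured step touching the group on the sulfonyl sulfur is a 10-fold lower number from compound 2 to compound 3 (1.00 log units; beyond the scatter), which does not involve 4-nitrophenyl. Compound 4 `COc1ccccc1C(=O)NCc1ccc(CNS(=O)(=O)c2ccc([N+](=O)[O-])cc2)cc1` differs from compound 1 by 4-nitrophenyl in place of 3-chlorophenyl on a sulfonyl sulfur. Because compound 1 gives 1000 nM and the entering group is again one six-membered aromatic ring of carbon only, no step beyond the scatter is expected, and the estimated change is no change at the digits printed from compound 1 to compound 4 (within the scatter). Compound 4 is therefore expected to give about 1000 nM, within 400 nM to 2500 nM.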

Compound 4, effective concentration (reported as EC, without a stated level of effect): 100 nM
Beside the measured number, compound 4's estimate is 10-fold (1.00 log units) above it; measured number below the stated range.
By their numbers in this assay, from the lowest: compounds 3 and 4 (each within the scatter of the next); then compounds 1 and 2 (each within the scatter of the next).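

In this assay, a 10-fold lower number from compound 1 to compound 4 (1.00 log units; beyond the scatter) shows that the group on the sulfonyl sulfur can move the number without any added ring: 3-chlorophenyl and 4-nitrophenyl are each one six-membered aromatic ring of carbon only. The earlier step at this place, a 10-fold lower number from compound 2 to compound 3 (1.00 log units; beyond the scatter), brought in naphthalen-1-yl and could not show this. Nothing given here bears on why the number changes. The compounds shown leave open whether the nitro group or its place on the ring carries the change, and how a phenyl bearing an amine or a carboxylic acid would read.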